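Series notes: nitrile warhead substituent, compound 3 to compound 4

The compounds below may be only part of what the source reports. "The series", "measured", "known", "first", "only" and "open" are said of these compounds alone.

Three analogues on the shared core of compound 1 `CC(C)C[C@H](NC(=O)N1CCOCC1)C(=O)N[C@H](C#N)CCc1ccccc1` have numbers in an assay for inhibition of cathepsin S (Homo sapiens); a lower number here means a stronger inhibitor, a higher number a weaker inhibitor. Compound 1 gives 47 nM. Compound 2 `CC(C)C[C@H](NC(=O)N1CCOCC1)C(=O)NCC#N` gives 124 nM. Compound 3 `CCCC[C@@H](C#N)NC(=O)[C@H](CC(C)C)NC(=O)N1CCOCC1` gives 56 nM. On these numbers compound 3 stands second highest of three: its number sits within the scatter of compound 1 and is separated from compound 2 by a step beyond the scatter.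

Compound 4 `CC(C)C[C@H](NC(=O)N1CCOCC1)C(=O)NC(C)(C)C#N` is the next member. The change is 1-cyano-1-methylethyl in place of 1-cyanopentyl on an amide-type nitrogen: the butyl chain and its defined stereocentre are given up for two methyl groups on the carbon bearing the nitrile.

Among the compounds with values here, two measured steps bear on the size of the group on that carbon. From compound 2 to compound 3 the addition of butyl gave a 2.2-fold lower number from compound 2 to compound 3 (0.35 log units; beyond the scatter). The step of a 2.6-fold higher number from compound 1 to compound 2 (0.42 log units; beyond the scatter) shows the loss of phenethyl in the other direction. Both are modest. Compound 4 keeps some substitution on that carbon but less than compound 3, so a step between the two measured ones is expected, in the direction of a higher number: a 1.8-fold higher number from compound 3 to compound 4 (0.25 log units; within the scatter) is the estimate. The expected value for compound 4 in this assay is 100 nM, with a range from 40 nM to 260 nM.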

Compound 4, half-maximal inhibitory concentration: 114 nM
Compound 4: middle estimate off by 1.1-fold (0.06 log units), on the low side, within the range that was stated.
By their numbers in this assay, from the lowest: compounds 1 and 3 (each within the scatter of the next); then compounds 4 and 2 (each within the scatter of the next).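

In this assay, exchanging 1-cyanopentyl for 1-cyano-1-methylethyl on the amide-type nitrogen gives a 2.0-fold higher number from compound 3 to compound 4 (0.31 log units; beyond the scatter), so the two methyl groups on the carbon bearing the nitrile do not match the butyl chain at this position. Set against cyanomethyl, which has no substituent on that carbon, 1-cyano-1-methylethyl gives a 1.1-fold lower number from compound 2 to compound 4 (0.04 log units; within the scatter), so on these numbers adding substitution at this carbon does not by itself lower the number; among the compounds shown, only the butyl and phenethyl chains do. Nothing measured here accounts for this difference.

The change from compound 3 to compound 4 alters the chain length, the number of groups on that carbon and the defined stereocentre at once, and the compounds shown do not separate these three. A single methyl group or a propyl chain on that carbon, or the opposite configuration of the carbon bearing the butyl chain, would show which of them goes with the lower number of compound 3.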